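A few compounds are considered here, and "the series" means these few. Any claim that something is new, unique, unknown or untested is made for them only; others in the source may bear on it.

Compound 1 `CC1=C(C(=O)OC(C)(C)C)C(c2csc(-c3ccc(Cl)cc3)n2)C(C(=O)OC(C)(C)C)=C(C)N1`: 21000 nM
Compound 2 `CCOC(=O)C1=C(C)NC(C)=C(C(=O)OC(C)C)C1c1csc(-c2ccc(Cl)cc2)n1`: 2550 nM
Compound 3 `COC(=O)C1=C(C)NC(C)=C(C(=O)OC(C)(C)C)C1c1csc(-c2ccc(Cl)cc2)n1`: 46000 nM

In an assay on isolated protein for antagonist activity at Voltage-dependent L-type calcium channel subunit alpha-1C (Cavia porcellus), with a stated time of 15 min (a lower number here means a stronger inhibitor, a higher number a weaker inhibitor), compound 3 gives the highest number of the three measured compounds, so it is the weakest inhibitor here. Compound 1 is nearest to it, and the step of a 2.2-fold higher number from compound 1 to compound 3 (0.34 log units; beyond the scatter) shows how a smaller ester group on one side raised the number. Among the compounds with values here, compound 2 lies far lower, with no single-change step connecting it to compound 3.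

Compound 4 `CCOC(=O)C1=C(C)NC(C)=C(C(=O)OC(C)(C)C)C1c1csc(-c2ccc(Cl)cc2)n1` differs from compound 3 by methyl in place of hydrogen on a saturated chain carbon bound to an oxygen next to a carbonyl group, so the smaller ester group grows by one carbon. Within the data shown here, the only step bearing on this, a 2.2-fold higher number from compound 1 to compound 3 (0.34 log units; beyond the scatter), went the other way when an ester group shrank. A modest lowering is therefore expected, a 2.1-fold lower number from compound 3 to compound 4 (0.32 log units; beyond the scatter), giving an estimated 22000 nM for compound 4, within 8000 nM to 55000 nM.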

Compound 4, half-maximal inhibitory concentration: 91000 nM
The estimate for compound 4 lay 4.1-fold (0.62 log units) below the measured number, outside the stated range (above it).
By their numbers in this assay, from the lowest: compound 2; then compound 1; then compounds 3 and 4 (each within the scatter of the next).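

In this assay, methoxycarbonyl to ethoxycarbonyl is a 2.0-fold higher number from compound 3 to compound 4 (0.30 log units; within the scatter), so this added methyl has no clear effect. The same methyl on a saturated chain carbon bound to an oxygen next to a carbonyl group and two saturated chain carbons gives a far larger step, a 36-fold higher number from compound 2 to compound 4 (1.55 log units; beyond the scatter), so its place matters. Ethyl in place of tert-butyl gives a 4.3-fold higher number from compound 1 to compound 4 (0.64 log units; beyond the scatter), which, like the methyl replacement, raises the number.

Nothing measured here explains these steps. From the compounds shown here alone, whether a longer chain, an amine or a carboxylic acid on this ester would lower the number remains open.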